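The compounds below may be only part of what the source reports. "The series", "measured", "known", "first", "only" and "open" are said of these compounds alone.

The study concerns three compounds measured in a functional assay on MIA PaCa-2 cells (Homo sapiens) for inhibition, read by MTT assay, with a stated time of 72 h (a higher number here means a weaker inhibitor, a lower number a stronger inhibitor), and a fourth still awaiting measurement. Within the data shown here, compound 1 `CC(C)(C)OC(=O)NCCNCC(=O)Nc1c[nH]c(=O)[nH]c1=O` is the only one with a number: in this assay compound 1 gives 50000 nM. Compound 2 `Cn1cc(CO)c(N)nc1=O` reaches only a limit of the assay, giving > 100000 nM in this assay. Compound 3 `Cc1cc(=O)[nH]c(=O)n1COC(CO)CO` also sits at a limit, with > 100000 nM in this assay. Compound 3 therefore stands not at a number but at the limit of > 100000 nM in this assay, at which 2 of the 3 values shown sit, a position it shares with compound 2.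

Compound 4 `Cc1c(I)c(=O)[nH]c(=O)n1COC(CO)CO` differs from compound 3 by iodo in place of hydrogen on an aromatic carbon. No step between measured compounds is shown, so there is no precedent among these compounds for what such a change does. Since compound 3 already stands at a limit, the step in this assay is expected to be none beyond the scatter, with no direction supported either way. The step that this expectation means is a number no higher from compound 3 to compound 4 (the limit leaves the size open). Compound 4 is estimated at 100000 nM, within a range from 30000 nM to 300000 nM, and is most likely to be reported only as a limit.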

Compound 4, half-maximal inhibitory concentration: > 100000 nM
Compound 4: no number, only a limit; the forecaster's own chance of this, stated with the estimate: 65%; the middle value sits exactly at the limit.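

Among these compounds, compound 3 and compound 4 both stand at a limit and not at a number, so no step between them can be read: the limit of > 100000 nM in this assay, at which 3 of the 4 values shown sit.

The compounds shown leave open what iodo in place of hydrogen on an aromatic carbon does in this assay, as neither compound of this pair carries a number there.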